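Methoxy in Place of Hydrogen on a Urea Series

The source may hold more compounds than are shown below. What is called first, only, known or untested is meant among the compounds shown, and "the series" means these compounds.

Compound 1 `Cc1cccc2c1cnn2-c1ccc(NC(=O)Nc2ccc(Cl)c(C(F)(F)F)c2)cc1` gives 4000 nM in a functional assay on HepG2 cells (Homo sapiens) for cytotoxicity, read by MTT assay, with a stated time of 72 h; on this read-out higher numbers stand for weaker inhibition and lower numbers for stronger inhibition.
Compound 2 `O=C(Nc1ccc(-n2ncc3ccccc32)cc1)Nc1ccc(Cl)c(C(F)(F)F)c1` gives 8000 nM in this assay.

Within the data shown here, compound 2 stands at the highest of the two numbers so far, and its nearest neighbour is compound 1, with a 2.0-fold higher number from compound 1 to compound 2 (0.30 log units; within the scatter), a difference that stays inside the scatter. Compound 3 `COc1cccc2c1cnn2-c1ccc(NC(=O)Nc2ccc(Cl)c(C(F)(F)F)c2)cc1` has not yet been measured and differs from compound 2 by methoxy in place of hydrogen on an aromatic carbon. Among the measured compounds shown here, the single measured step that bears on this position is the one from compound 1 to compound 2, a change of methyl to hydrogen at the same aromatic carbon, and it was within the scatter. On that basis no step beyond the scatter is expected for a methoxy at this position, and the estimated step is a 1.3-fold lower number from compound 2 to compound 3 (0.12 log units; within the scatter). Compound 3 is therefore expected to give about 6000 nM in this assay, with a range from 2000 nM to 18000 nM.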

Compound 3, half-maximal inhibitory concentration: 4000 nM
For compound 3 the middle estimate is 1.5-fold (0.18 log units) above the measured one; low and high end bracket the measured number.
By their numbers in this assay, from the lowest: compounds 1, 3 and 2 (each within the scatter of the next).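

In this assay methoxy in place of hydrogen on this aromatic carbon brings a 2.0-fold lower number from compound 2 to compound 3 (0.30 log units; within the scatter) and methoxy in place of methyl brings no change at the digits printed from compound 1 to compound 3 (within the scatter) on the same carbon. With hydrogen, methyl and methoxy now all read here, this position has taken a group of two heavy atoms, one of them oxygen, without any step leaving the scatter, and the three compounds cannot be put in order. No measurement is at hand that would explain this result.

As far as these compounds go, whether another group on this carbon, such as an amine, a carboxylic acid or a longer chain, would give a step beyond the scatter stays open. Also open, from the compounds shown here alone, is whether methoxy on a different carbon of the same ring would read as it does here.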